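Benzyloxy in Place of Methoxycarbonylphenyl on a Shared Core

The compounds below may be only part of what the source reports. "The series", "measured", "known", "first", "only" and "open" are said of these compounds alone.

In an assay on isolated protein for agonist activity at Bile acid receptor (Homo sapiens), read by AlphaScreen, with a stated time of 30 min (a lower number here means that less compound is needed, a higher number that more compound is needed for the effect), compound 1 `Cc1nn(-c2ccccc2I)c2c1C(c1ccc(Oc3ccccc3)cc1)SC(C)C(=O)N2` gives 1300 nM and compound 2 `Cc1ccc(-n2nc(C)c3c2NC(=O)[C@H](C)S[C@@H]3c2ccc(Oc3ccccc3)cc2)cc1` gives 3400 nM. Compound 3 `COC(=O)c1ccc(-c2ccc([C@H]3S[C@@H](C)C(=O)Nc4c3c(C)nn4-c3ccccc3C)cc2)cc1`, in which a 4-(methoxycarbonyl)phenyl group sits on the outer aromatic ring, is reported in this assay only as "not active" (no number reported), so no single number marks where it stands. Compound 4 `Cc1ccccc1-n1nc(C)c2c1NC(=O)[C@H](C)S[C@@H]2c1ccc(OCc2ccccc2)cc1` differs from compound 3 by benzyloxy in place of 4-(methoxycarbonyl)phenyl on an aromatic carbon. Because compound 3 gives "not active" (no number reported), a step in this assay toward a measurable concentration is expected, in the direction of less compound needed, since the two compounds that carry an oxygen-linked aromatic group at that place, compound 1 and compound 2, each give a number. Compound 4 is therefore expected to give about 2500 nM in this assay, between 600 nM and 15000 nM.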

Compound 4, half-maximal effective concentration: "not active" (no number reported)
Compound 4 has no reported number here, and the estimate cannot be compared.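

In this assay compound 3 and compound 4 are both reported only as "not active", so no step can be read between them. No evidence bears on this result. The compounds shown leave open how benzyloxy and 4-(methoxycarbonyl)phenyl compare on the shared core.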